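Fluoro in place of methoxymethoxy on the side chain

The source may report more compounds than this note shows. Statements on the series, on what has been measured and on what is new or still open speak of the compounds shown alone.

Measured compounds:
Compound 1 `COc1ccc(C[S+]([O-])c2ncccc2C(=O)Nc2ccncc2)c(OC)c1OC`: 116 h
Compound 2 `COc1ccc(C[S+]([O-])c2ncccc2C(=O)Nc2ccncc2)c(OCCO)c1`: 1.78 h
Compound 3 `COCOCCOc1cc(OC)ccc1C[S+]([O-])c1ncccc1C(=O)Nc1ccncc1`: 2.75 h

Of the compounds shown here, three with a shared core have been measured in an ADME assay; a lower number here means that the compound disappears faster, a higher number that the compound lasts longer. Compound 1 gives 116 h, by far the highest of the three. Compound 2 gives 1.78 h and compound 3 gives 2.75 h, so compound 3 sits second of the three, close to compound 2 and far from compound 1. Going by the values given here, the only single-point step among them, a 1.5-fold higher number from compound 2 to compound 3 (0.19 log units; within the scatter), introduces methoxymethyl in place of hydrogen on an oxygen on a saturated carbon and stays within the scatter.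

Compound 4 `COc1ccc(C[S+]([O-])c2ncccc2C(=O)Nc2ccncc2)c(OCCF)c1` is not yet measured. Its change from compound 3 is fluoro in place of methoxymethoxy on a saturated chain carbon, two bonds along the chain from an oxygen on an aromatic ring. Among the compounds with values here, no measured step covers fluoro entering at this spot, so the step from compound 2 to compound 3 is the only guide: altering the end of this side chain did not move the number beyond the scatter there. Within the data shown here, compound 1 shows that a quite different substitution pattern can give a much higher number, but it differs in more than one place, so it offers no single-point step.

For compound 4 a half-life near that of compound 3 is therefore expected, a 1.3-fold higher number from compound 3 to compound 4 (0.10 log units; within the scatter), with the estimate 3.5 h and a range from 1.2 h to 10 h.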

Compound 4, half-life: 3.3 h
Estimate against measurement, compound 4: 1.1-fold (0.03 log units) above; the measured number falls inside the stated range.
By their numbers in this assay, from the lowest: compounds 2, 3 and 4 (each within the scatter of the next); then compound 1.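

In this assay, swapping the whole methoxymethoxy group for a single fluoro, on a saturated chain carbon two bonds along the chain from an oxygen on an aromatic ring, gives a 1.2-fold higher number from compound 3 to compound 4 (0.08 log units; within the scatter), so this much larger exchange at the chain end leaves the half-life where it was. The second comparison, a direct exchange of hydroxy for fluoro at the same place, gives a 1.9-fold higher number from compound 2 to compound 4 (0.27 log units; within the scatter), so hydroxy, methoxymethoxy and fluoro, three quite different ends, cannot be told apart at this position in these compounds. Nothing measured here accounts for this lack of difference.

The compounds shown leave open whether an amine or a carboxylic acid at this chain end, or a longer chain in place of the 2-fluoroethoxy group, would also stay within the scatter. They also leave open what sets compound 1, at 116 h, apart, since it differs from the others in more than one place and no single change can be read from it.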